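The source may report more compounds than this note shows. Statements on the series, on what has been measured and on what is new or still open speak of the compounds shown alone.

In a functional assay on MCF7 cells (Homo sapiens) for antiproliferative activity, read by MTT assay, with a stated time of 72 h (a lower number here means a stronger inhibitor, a higher number a weaker inhibitor), compound 1 `C#CCSc1nc(Sc2nnnn2CCN(C)C)c(C#N)c(-c2ccc(Cl)cc2)n1` gives 6180 nM and compound 2 `C#CCSc1nc(Sc2nccs2)c(C#N)c(-c2ccc(Cl)cc2)n1` gives 3230 nM. Compound 3 `C#CCSc1nc(Sc2nc(C)cs2)c(C#N)c(-c2cc(OC)c(OC)c(OC)c2)n1` reports only a limit, > 20000 nM. Compound 2 therefore stands with compound 1, and no measured number separates them beyond the scatter. Among the compounds with values here, the one measured step, a 1.9-fold lower number from compound 1 to compound 2 (0.28 log units; within the scatter), concerns a group on a sulfur.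

Compound 4 `C#CCSc1nc(Sc2nccs2)c(C#N)c(-c2ccc[nH]2)n1` has 1H-pyrrol-2-yl in place of 4-chlorophenyl on an aromatic carbon, ortho to a cyano group: 1H-pyrrol-2-yl in place of 4-chlorophenyl on an aromatic carbon. The step on sulfur does not touch this carbon, so it gives no direct size for the change. Compound 3 also carries a different group at this carbon, but it differs from compound 2 on the sulfur group too. A moderate move toward a higher number is expected in this assay because the limit of compound 3 is > 20000 nM, though this is weak support. The expected change is a 1.7-fold higher number from compound 2 to compound 4 (0.23 log units; within the scatter). For compound 4 the estimated value is 5500 nM, with an expected range from 1500 nM to 19000 nM.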

Compound 4, half-maximal inhibitory concentration: > 20000 nM
Compound 4 ended at the assay's limit; the forecaster's own chance of this, stated with the estimate: 20%; at least 3.6-fold (0.56 log units) between middle value and limit.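

In this assay, within the data shown here, this carbon, ortho to a cyano group, gives the first step beyond the scatter, an at least 6.1-fold higher number from compound 2 to compound 4 (0.79 log units; beyond the scatter), when 1H-pyrrol-2-yl takes the place of 4-chlorophenyl. The earlier step on the sulfur, a 1.9-fold lower number from compound 1 to compound 2 (0.28 log units; within the scatter), stayed within the scatter, and compound 3 differs from compound 2 in two places, so it could not size a change at this carbon. Compound 4 reports only a limit, > 20000 nM, and the step gives a lower bound rather than a full size because the reading stops there: the limit of > 20000 nM in this assay, at which 2 of the 4 values shown sit.

This step changes three things at once: the chlorine is lost, the ring changes, and a hydrogen enters on the pyrrole nitrogen. The compounds shown do not separate these three changes. A plain phenyl and a pyrrole with a methyl on its nitrogen at this carbon would separate these changes.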